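The compounds below may be only part of what the source reports. "The series", "measured", "known", "first", "only" and "open" are said of these compounds alone.

In an assay on a protein complex for inhibition of integrin alpha-5/beta-1 (Homo sapiens), read by ELISA (a lower number here means a stronger inhibitor, a higher number a weaker inhibitor), compound 1 `Cc1cc(C)c(C(=O)N[C@@H](CNC(=O)CO[C@@H]2C[C@@H](CNc3ccccn3)N(C(=O)OCc3ccccc3)C2)C(=O)O)c(C)c1` gives 3.5 nM, the second highest of the three numbers in hand. Compound 2 `COc1ccnc(NC[C@@H]2C[C@@H](OCC(=O)NC[C@H](NC(=O)C3(C)CCCCC3)C(=O)O)CN2C(=O)CC(C)(C)C)c1` gives 0.55 nM in this assay, and compound 3 `O=C(CO[C@@H]1C[C@@H](CNc2ccccn2)N(C(=O)OCc2ccccc2)C1)NC[C@H](NC(=O)c1ccccc1)C(=O)O` gives 155 nM. Among the measured compounds shown here, the only single-point step measured, a 44-fold higher number from compound 1 to compound 3 (1.65 log units; beyond the scatter), concerns the acyl group on the amide and not the ring that is altered here, so it does not bear on the present change. Compound 4 `COc1ccnc(NC[C@@H]2C[C@@H](OCC(=O)NC[C@H](NC(=O)c3c(C)cc(C)cc3C)C(=O)O)CN2C(=O)OCc2ccccc2)c1` differs from compound 1 by methoxy in place of hydrogen on an aromatic carbon. Compound 2 carries the same methoxy on its ring, among several other differences, and its number lies well below that of compound 1; that pair isolates nothing, but it gives no sign that the methoxy pushes the number up. For the measured compounds named here, with no step that speaks to the change alone, the expectation for this assay is a step of at most modest size toward a lower number, or none beyond the scatter, written as a 1.8-fold lower number from compound 1 to compound 4 (0.24 log units; within the scatter). On that basis compound 4 is estimated at 2 nM, expected to fall between 0.7 nM and 6 nM.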

Compound 4, half-maximal inhibitory concentration: 0.54 nM
Compound 4: middle estimate off by 3.7-fold (0.57 log units), on the high side; measured number below the stated range.
By their numbers in this assay, from the lowest: compounds 4 and 2 (each within the scatter of the next); then compound 1; then compound 3.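

Among the compounds shown here, the step of a 6.5-fold lower number from compound 1 to compound 4 (0.81 log units; beyond the scatter) in this assay is the first reading of this change on its own, since the earlier compounds either lacked the methoxy or carried it among several other differences. It shows that going from pyridin-2-yl to 4-methoxypyridin-2-yl, with the methoxy opposite the ring nitrogen, moves the number down beyond the scatter on an otherwise unchanged structure. Nothing available accounts for the size of this step.

The compounds shown leave open whether a methyl, an amine, a chlorine or a longer chain such as ethoxy at this same position would give a similar step. They also leave open whether the methoxy would give a step of this size on compound 3, with its unsubstituted phenyl on the carbonyl carbon.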